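The compounds below may be only part of what the source reports. "The series", "measured", "known", "first", "only" and "open" are said of these compounds alone.

Three compounds of the series have numbers in a functional assay, with a stated time of 10 min; a higher number here means a weaker inhibitor, a lower number a stronger inhibitor. Compound 1 `Cn1c(NN)nc(-c2cccc(O)c2O)c(C#N)c1=O` gives 29 ug/mL in this assay. Compound 3 `Cn1c(NN)nc(-c2ccco2)c(C#N)c1=O` gives 58 ug/mL in this assay. Compound 2 `CCOC(=O)c1cnn(-c2nc(-c3ccccc3Cl)c(C#N)c(=O)n2C)c1N` gives 98 ug/mL in this assay, the highest of the three numbers; its gap to compound 3 lies within the scatter, while its gap to compound 1 lies beyond it. The unmeasured compound 4 `CCOC(=O)c1cnn(-c2nc(-c3ccc(OC)cc3)c(C#N)c(=O)n2C)c1N` is made from compound 2 by a single change: 4-methoxyphenyl in place of 2-chlorophenyl on an aromatic carbon. For the measured compounds named here, no pair of measured compounds differs in only one place, so no measured step shows what this change does, and the three compounds measured so far cover a different set of groups on the shared core. In this assay no step beyond the scatter is expected in either direction when going from compound 2 to compound 4. Compound 4 is estimated at 90 ug/mL in this assay, with a range of 40 ug/mL to 200 ug/mL. The expected step is a 1.1-fold lower number from compound 2 to compound 4 (0.04 log units; within the scatter).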

Compound 4, half-maximal inhibitory concentration: 74 ug/mL
Beside the measured number, compound 4's estimate is 1.2-fold (0.09 log units) above it, and the stated range covers the measured number.
By their numbers in this assay, from the lowest: compounds 1, 3, 4 and 2 (each within the scatter of the next, the first and the last beyond it).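

In this assay, for the compounds shown here, the replacement of 2-chlorophenyl by 4-methoxyphenyl gives a 1.3-fold lower number from compound 2 to compound 4 (0.12 log units; within the scatter) and is the first single-place step available. At this aromatic carbon, opposite the ring nitrogen and ortho to the cyano group, the two aryl groups therefore cannot be told apart in this read-out, even though the change alters both the substituent and where it sits on the phenyl ring. Nothing available explains this result.

The step changes both features at once. 4-chlorophenyl and 2-methoxyphenyl would be needed to show whether either one matters on its own. Whether this position responds at all also remains open, as the two aryl groups shown say nothing about an unsubstituted phenyl, a carboxylic acid on the phenyl ring or an aliphatic amine.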